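This account rests on a few compounds, and the source may have more. Where it says the series, first, only, none or still open, it means among the compounds named here.

Three compounds built on a shared core have been examined so far in an ADME assay on CCRF-CEM cells (Homo sapiens) for cytotoxicity, read by MTT assay, with a stated time of 72 h; a higher number here means that more compound is tolerated, a lower number that less compound is tolerated. Only one of them gave a number: compound 2 `CC(=O)c1c(O)c(C(C)=O)c(O)c(C(c2c(O)c(C(C)=O)c(O)c(C(C)=O)c2O)C2CCCCC2)c1O` reads 58900 nM. Compound 1 `CC(=O)c1c(O)c(C(C)=O)c(O)c(C(CCc2ccccc2)c2c(O)c(C(C)=O)c(O)c(C(C)=O)c2O)c1O` has no usable result, its entry being "not determined" (no result reported). Compound 3 `CC(=O)c1c(O)c(C(C)=O)c(O)c(C(c2ccc(O)cc2)c2c(O)c(C(C)=O)c(O)c(C(C)=O)c2O)c1O` is in the same position, with the entry "not determined" (no result reported), so it cannot be ranked against anything on the numbers available.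

The next structure, compound 4 `CC(=O)c1c(O)c(C(C)=O)c(O)c(C(c2c(O)c(C(C)=O)c(O)c(C(C)=O)c2O)c2ccnc3ccccc23)c1O`, keeps the shared core and changes a single group. Quinolin-4-yl takes the place of 4-hydroxyphenyl on a saturated chain carbon bound to two aromatic carbons: quinolin-4-yl in place of 4-hydroxyphenyl on a saturated chain carbon bound to two aromatic carbons.

With no value for compound 3, this change has no measured starting point, and no measured step between any two of these compounds can serve as a guide. For the measured compounds named here, the only anchor is compound 2 at 58900 nM, and a single value shows no trend. The working expectation is therefore a modest step from that anchor towards less compound being tolerated, possibly no larger than the scatter of repeated measurements, and this direction is held only loosely.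

For compound 4, the estimated value in this assay is 30000 nM, with an expected range from 8000 nM to 100000 nM.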

Compound 4, half-maximal cytotoxic concentration: 93400 nM
Compound 4: middle estimate off by 3.1-fold (0.49 log units), on the low side; measured number inside the range.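

In this assay, the place on a saturated chain carbon bound to two aromatic carbons now has two measured groups, cyclohexyl and quinolin-4-yl, and they can be compared directly: the step is a 1.6-fold higher number from compound 2 to compound 4 (0.20 log units; within the scatter). For the compounds shown here, this pair therefore gives the first reading of a change at this place, and it shows that replacing cyclohexyl with quinolin-4-yl gives no difference that can be separated from the ordinary spread of repeated measurements. The change from 4-hydroxyphenyl to quinolin-4-yl cannot be read, as compound 3 has no number, and no measured evidence is available to explain the result.

From the compounds shown here alone, the two groups with numbers both place a ring at this position, so it remains open how an open chain such as butyl, or a phenyl ring carrying a carboxylic acid or an amine, would read here. Whether any group at this place can move the number beyond the scatter also remains unanswered by these compounds.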